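Azido for methoxymethoxy: little change expected

A few compounds are considered here, and "the series" means these few. Any claim that something is new, unique, unknown or untested is made for them only; others in the source may bear on it.

In a functional assay on MCF7 cells (Homo sapiens) for antiproliferative activity, read by MTT assay, with a stated time of 48 h (a higher number here means a weaker inhibitor, a lower number a stronger inhibitor), compound 3 (`COCOC/C1=C/C[C@](C)(CCC=C(C)C)/C=C/[C@@H](OC(=O)C=C(C)C)[C@](C)(O)/C=C/C1=O`) gives 3120 nM, at the high end of the three measured numbers. Compound 1 (`CC(=O)OC/C1=C/C[C@](C)(CCC=C(C)C)/C=C/[C@@H](OC(=O)C=C(C)C)[C@](C)(O)/C=C/C1=O`) sits alongside it at 4510 nM, and the step between them is small: a 1.4-fold lower number from compound 1 to compound 3 (0.16 log units; within the scatter). Compound 2 (`CC(C)=CCC[C@]1(C)/C=C/[C@@H](OC(=O)C=C(C)C)[C@](C)(O)/C=C/C(=O)/C(CN2CCCC2)=C\C1`), with pyrrolidin-1-yl on the same carbon, gives 220 nM. The steps involving it are large: a 21-fold lower number from compound 1 to compound 2 (1.31 log units; beyond the scatter), and a 14-fold higher number from compound 2 to compound 3 (1.15 log units; beyond the scatter).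

Compound 4 (`CC(C)=CCC[C@]1(C)/C=C/[C@@H](OC(=O)C=C(C)C)[C@](C)(O)/C=C/C(=O)/C(CN=[N+]=[N-])=C\C1`) has azido in place of methoxymethoxy on a saturated chain carbon bound to a double-bonded ring carbon. For the measured compounds named here, no azido compound has been measured, so the small step is the closer guide, though an uncertain one. The expected change in this assay stays within the scatter: a 1.1-fold lower number from compound 3 to compound 4 (0.05 log units; within the scatter). Compound 4 is estimated at 2800 nM, with an expected range of 1000 nM to 7000 nM.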

Compound 4, half-maximal inhibitory concentration: 4890 nM
The estimate for compound 4 lay 1.7-fold (0.24 log units) below the measured number; measured number inside the range.
By their numbers in this assay, from the lowest: compound 2; then compounds 3, 1 and 4 (each within the scatter of the next).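

In this assay, the azido group behaves like the oxygen-linked groups at this carbon: a 1.6-fold higher number from compound 3 to compound 4 (0.20 log units; within the scatter) and a 1.1-fold higher number from compound 1 to compound 4 (0.04 log units; within the scatter). Nitrogen bound to this carbon is therefore not enough by itself, as a 22-fold higher number from compound 2 to compound 4 (1.35 log units; beyond the scatter) shows, and among these compounds only pyrrolidin-1-yl stands apart. Nothing measured here explains that difference. From the compounds shown here alone, whether the ring of pyrrolidin-1-yl matters remains open. An open-chain amine such as dimethylamino, or a larger ring amine such as piperidin-1-yl, would help to separate the amine nitrogen from the ring.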